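A sulfamoyl swap on an unmeasured aryl triazole

The source may hold more compounds than are shown below. What is called first, only, known or untested is meant among the compounds shown, and "the series" means these compounds.

Compound 3 `CCOc1ccc(-n2nncc2CN2C(=O)C3(C(C#N)=C(N)Oc4c3c3nc5ccccc5nc3c3ccccc43)c3ccccc32)cc1` reaches only a limit in a functional assay on HCT-116 cells (Homo sapiens) for antiproliferative activity, read by MTT assay, with a stated time of 48 h (on this read-out lower numbers stand for stronger inhibition and higher numbers for weaker inhibition), namely > 50000 nM. Compound 1 `Cc1cccc(-n2nncc2CN2C(=O)C3(C(C#N)=C(N)Oc4c3c3nc5ccccc5nc3c3ccccc43)c3ccccc32)c1` likewise stops at the limit > 50000 nM in this assay. Compound 2 `CCOc1ccccc1-n1nncc1CN1C(=O)C2(C(C#N)=C(N)Oc3c2c2nc4ccccc4nc2c2ccccc32)c2ccccc21` also gives only the limit > 50000 nM. Because all three values sit at the limit of > 50000 nM in this assay, at which 3 of the 3 values shown sit, the steps a step that the two limits leave unreadable from compound 1 to compound 3, a step that the two limits leave unreadable from compound 2 to compound 3 and a step that the two limits leave unreadable from compound 1 to compound 2 cannot be read. Compound 4 `N#CC1=C(N)Oc2c(c3nc4ccccc4nc3c3ccccc23)C12C(=O)N(Cc1cnnn1-c1ccc(S(N)(=O)=O)cc1)c1ccccc12` differs from compound 3 by sulfamoyl in place of ethoxy on an aromatic carbon. The measured steps alter the same aryl ring yet offer no readable size, so no direction can be drawn from them. Compound 4 is therefore expected to remain near the limit, at about 60000 nM, between 20000 nM and 200000 nM. The step that the limit leaves unreadable from compound 3 to compound 4 implied by this estimate is expected to be small.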

Compound 4, half-maximal inhibitory concentration: 31200 nM
Estimate against measurement, compound 4: 1.9-fold (0.28 log units) above; low and high end bracket the measured number.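

In this assay only compound 4 gives a number rather than a limit: the limit of > 50000 nM in this assay, at which 3 of the 4 values shown sit. Sulfamoyl in place of ethoxy gives an at least 1.6-fold lower number from compound 3 to compound 4 (0.20 log units; that floor lies within the scatter) and the swaps of the whole aryl group give an at least 1.6-fold lower number from compound 2 to compound 4 (0.20 log units; that floor lies within the scatter) and an at least 1.6-fold lower number from compound 1 to compound 4 (0.20 log units; that floor lies within the scatter) as floors that lie within the scatter, so a real gain is not shown and the true size of these steps stays unknown. Still open, from the compounds shown here alone, is whether an amine or a carboxylic acid on this ring would give a clearly lower number, and whether sulfamoyl is special at this place.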